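Aryl group changes and KB cell growth inhibition

The source may report more compounds than this note shows. Statements on the series, on what has been measured and on what is new or still open speak of the compounds shown alone.

Measured compounds:
Compound 1 `CCC1=C(O)c2c(oc(-c3ccc(SC)cc3)cc2=O)C(CC)(CC)C1=O`: in a functional assay on KB cells (Homo sapiens) for antiproliferative activity, read by sulforhodamine B assay, with a stated time of 3 days (a lower number here means that less compound is needed, a higher number that more compound is needed for the effect), compound 1 gives > 52.1 uM, a limit of the assay rather than a number.
Compound 2 `CCC1=C(O)c2c(oc(-c3cccc(F)c3)cc2=O)C(CC)(CC)C1=O`: compound 2 gives > 56.2 uM, likewise a limit.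
Compound 3 `CCC1=C(O)c2c(oc(-c3cc(C)c(C)cc3C)cc2=O)C(CC)(CC)C1=O`: compound 3 gives 8.2 uM.

Compound 1 therefore stands only at a limit, as does compound 2, and compound 3 alone has a measured number. Compound 4 `CCC1=C(O)c2c(oc(-c3ccc(OC)c(F)c3)cc2=O)C(CC)(CC)C1=O` differs from compound 1 in one place: 3-fluoro-4-methoxyphenyl in place of 4-(methylsulfanyl)phenyl on an aromatic carbon.

Of the measured steps, the change from compound 1 to compound 2 gives a step that the two limits leave unreadable from compound 1 to compound 2. The steps of an at least 6.3-fold lower number from compound 1 to compound 3 (0.80 log units; beyond the scatter) and an at least 6.8-fold lower number from compound 2 to compound 3 (0.83 log units; beyond the scatter) show that the 2,4,5-trimethylphenyl brings a clearly lower number than either of the other two groups. The entering 3-fluoro-4-methoxyphenyl resembles the 4-(methylsulfanyl)phenyl of compound 1 and the 3-fluorophenyl of compound 2 more than it resembles the 2,4,5-trimethylphenyl of compound 3, so no step beyond the scatter is expected, and a further limit is the more likely outcome, in line with the limit of > 52.1 uM in this assay, at which 1 of the 3 values shown sits, and (the limit of > 56.2 uM in this assay, at which 1 of the 3 values shown sits). The expected step is a step that the limit leaves unreadable from compound 1 to compound 4. Compound 4 is estimated at 60 uM, within 15 uM to 200 uM.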

Compound 4, concentration for half-maximal effect: 26.7 uM
Beside the measured number, compound 4's estimate is 2.2-fold (0.35 log units) above it, and the stated range covers the measured number.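

Compound 4 is the second compound here to give a real number in this assay, so a measured value at this position is not confined to the 2,4,5-trimethylphenyl, although the change to the 3-fluoro-4-methoxyphenyl still gives a 3.3-fold higher number from compound 3 to compound 4 (0.51 log units; beyond the scatter). Adding a methoxy to the 3-fluorophenyl gives an at least 2.1-fold lower number from compound 2 to compound 4 (0.32 log units; beyond the scatter), whereas the swap from the 4-(methylsulfanyl)phenyl gives an at least 1.9-fold lower number from compound 1 to compound 4 (0.29 log units; that floor lies within the scatter), so that swap cannot be called a gain. The methoxy step is only a floor, because compound 2 stands at a limit of the assay: the limit of > 56.2 uM in this assay, at which 1 of the 4 values shown sits.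

Going by these compounds, whether a 4-methoxyphenyl without the fluorine, or an ethoxy or dimethylamino group in place of the methoxy, would give a lower number than compound 4 stays open. On these data alone, how far the true numbers of compound 1 and compound 2 lie beyond their limits also stays open.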